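A few compounds are considered here, and "the series" means these few. Any claim that something is new, unique, unknown or untested is made for them only; others in the source may bear on it.

Compound 1 `Cc1cccc(-n2cc(-c3ccccc3NS(=O)(=O)c3c[nH]c(=O)[nH]c3=O)nn2)c1`, compound 2 `O=c1[nH]cc(S(=O)(=O)Nc2ccccc2-c2cn(-c3ccccc3Cl)nn2)c(=O)[nH]1` and compound 3 `Cc1ccccc1-n1cc(-c2cccc(NS(=O)(=O)c3c[nH]c(=O)[nH]c3=O)c2)nn1` make up the measured set.

In a functional assay on HepG2 cells (Homo sapiens) for antiproliferative activity, read by MTT assay, with a stated time of 24 h (on this read-out higher numbers stand for weaker inhibition and lower numbers for stronger inhibition), compound 1 gives 3620 nM, compound 2 gives 2240 nM and compound 3 gives 9570 nM. Compound 3 therefore stands highest of the three, beyond the scatter from both compound 1 and compound 2. The step to compound 4 `O=c1[nH]cc(S(=O)(=O)Nc2cccc(-c3cn(-c4cccc(Cl)c4)nn3)c2)c(=O)[nH]1` is 3-chlorophenyl in place of 2-methylphenyl on an aromatic nitrogen. Within the data shown here, the only measured step at the same place, a 1.6-fold lower number from compound 1 to compound 2 (0.21 log units; within the scatter), also swapped a methylphenyl for a chlorophenyl, though with the substituents at different positions, and it stayed within the scatter. On that basis no step beyond the scatter is expected, a 1.4-fold lower number from compound 3 to compound 4 (0.14 log units; within the scatter), and compound 4 is estimated at 7000 nM with a range from 3000 nM to 16000 nM.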

Compound 4, half-maximal inhibitory concentration: 4200 nM
For compound 4 the middle estimate is 1.7-fold (0.22 log units) above the measured one, within the range that was stated.
By their numbers in this assay, from the lowest: compounds 2, 1 and 4 (each within the scatter of the next); then compound 3.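

In this assay, 3-chlorophenyl in place of 2-methylphenyl on the aromatic nitrogen gives a 2.3-fold lower number from compound 3 to compound 4 (0.36 log units; beyond the scatter), a modest step. It shows that the number at this position can move beyond the scatter, which the earlier methylphenyl-to-chlorophenyl swap, a 1.6-fold lower number from compound 1 to compound 2 (0.21 log units; within the scatter), did not show. Nothing available bears on the reason for this step.

Going by these compounds, whether the step follows the chlorine or its place on the phenyl ring stays open, since the two groups differ in both. Also open, on these data alone, is how this assay would read with an amine or a carboxylic acid on that phenyl ring, or with a longer alkyl chain in its place.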